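Dimethylamino for acetyl on the phenyl of compound 1

The source may hold more compounds than are shown below. What is called first, only, known or untested is meant among the compounds shown, and "the series" means these compounds.

Measured compounds:
compound 1 `COc1cc(C)cc(-c2c(-c3ccnc(-c4ccc(C(C)=O)cc4)c3)cnn2CC#N)c1` gives 7%
compound 2 `Cc1cc(O)cc(-c2nn(CC#N)cc2-c2ccnc(-c3ccc(Oc4ccccc4)cc3)c2)c1` gives -65%
compound 3 `Cc1cc(O)cc(-c2nn(CC#N)cc2-c2ccnc(-c3ccc(N(C)C)cc3)c2)c1` gives 24%

In a functional assay on HT-29 cells (Homo sapiens) for cytotoxicity, read by sulforhodamine B assay, with a stated time of 48 h, tested at 1 uM (a higher number here means a weaker effect of the compound at the concentration tested, a lower number a stronger effect), compound 1 stands second highest of the three numbers; compound 3 sits higher and compound 2 lies far lower, both beyond the scatter. Compound 4 `COc1cc(C)cc(-c2c(-c3ccnc(-c4ccc(N(C)C)cc4)c3)cnn2CC#N)c1` is not yet measured. It differs from compound 1 by dimethylamino in place of acetyl on an aromatic carbon. Within the data shown here, no measured step carries exactly this change. Among the measured compounds shown here, the only measured step, a number 89 percentage points higher from compound 2 to compound 3 (beyond the scatter), shares the entering dimethylamino but leaves phenoxy, not acetyl, and sits on a core bearing hydroxy rather than methoxy, so it can only be read loosely. Compound 3, which already carries dimethylamino, gives 24%, and compound 1, with acetyl, gives 7%; these two values sit apart beyond the scatter but differ in two places. On this basis a modest upward step is expected, a number 11 percentage points higher from compound 1 to compound 4 (beyond the scatter), though a step within the scatter would not be surprising. Compound 4 is estimated at 18%, with a range from -5% to 40%.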

Compound 4, a percentage reported as activity, at one concentration (the size of the read-out at that concentration, not a potency): -51%
For compound 4 the middle estimate is 69 percentage points above the measured one; the whole stated range lies above it.
By their numbers in this assay, from the lowest: compound 2; then compound 4; then compound 1; then compound 3.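

In this assay the swap on the phenyl ring gives a number 58 percentage points lower from compound 1 to compound 4 (beyond the scatter), which shows that this position responds strongly even to an exchange of groups with equal heavy-atom counts, neither carrying a ring or a net charge. The earlier step, a number 89 percentage points higher from compound 2 to compound 3 (beyond the scatter), ran the opposite way with the same entering dimethylamino, so across these two pairs dimethylamino has no fixed direction and the outcome differs with the group it replaces and the core that carries it. Nothing at hand explains this reversal.

The compounds shown leave open how a primary amine, a morpholine or a carboxylic acid would read at this place on the phenyl ring. They also leave open whether acetyl on the hydroxy-bearing core would follow the same course.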